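The source may report more compounds than this note shows. Statements on the series, on what has been measured and on what is new or still open speak of the compounds shown alone.

Measured so far:
- compound 1, `C=CC(=O)N1CC[C@H](N2C(=O)N(Cc3ccccc3)Cc3cnc(Nc4ccc(N5CCN(C)CC5)cc4OC)nc32)C1`: 240 mL/min/kg
- compound 2, `C=CC(=O)N1CC[C@H](N2C(=O)N(c3ccccc3)Cc3cnc(Nc4ccc(N5CCN(C)CC5)cc4)nc32)C1`: 96.7 mL/min/kg

Going by the values given here, in an ADME assay on the whole organism (strain Sprague-Dawley) for pharmacokinetics, with Rattus norvegicus as the target, read by LC-MS, at a dose of 5 mg/kg by the intravenous route (on this read-out lower numbers stand for slow clearance and higher numbers for fast clearance), compound 2 gives 96.7 mL/min/kg, the lower of the two numbers known here. Compound 1 gives 240 mL/min/kg in this assay, a difference that lies beyond the usual scatter. Compound 1 and compound 2 differ in two places at once, so no single change can be read from that pair.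

Compound 3, `C=CC(=O)N1CC[C@H](N2C(=O)N(c3ccccc3)Cc3cnc(Nc4ccc(N5CCN(C)CC5)cc4OC)nc32)C1`, has not yet been measured in this assay. It differs from compound 2 in one place only: methoxy in place of hydrogen on an aromatic carbon. Compound 1 carries this same methoxy and shows the higher number, but it also carries a different group elsewhere, so the data give no clean guide. A modest rise in clearance, possibly within the scatter, is the expectation for compound 3, as a 1.3-fold higher number from compound 2 to compound 3 (0.13 log units; within the scatter). Compound 3 is therefore estimated at 130 mL/min/kg in this assay, within a range from 65 mL/min/kg to 260 mL/min/kg.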

Compound 3, clearance: 86.7 mL/min/kg
Compound 3: middle estimate off by 1.5-fold (0.18 log units), on the high side, within the range that was stated.
By their numbers in this assay, from the lowest: compounds 3 and 2 (each within the scatter of the next); then compound 1.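

In this assay, methoxy in place of hydrogen on the aromatic carbon ortho to a large group gives a 1.1-fold lower number from compound 2 to compound 3 (0.05 log units; within the scatter), so with phenyl on the nitrogen this change cannot be told apart from the usual scatter. The other change can now be read alone: phenyl in place of benzyl on an amide-type nitrogen in a ring gives a 2.8-fold lower number from compound 1 to compound 3 (0.44 log units; beyond the scatter), so among these compounds a step beyond the scatter appears with this change and not with the methoxy. No measurement at hand explains either step.

The compounds shown leave open whether methoxy behaves the same way with benzyl on that nitrogen. Also open, going by these compounds, is what a fluorine atom or an amine on the same aromatic carbon, or a longer chain on the nitrogen, would give in this assay.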